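A few compounds are considered here, and "the series" means these few. Any claim that something is new, unique, unknown or untested is made for them only; others in the source may bear on it.

Measured compounds:
compound 1, `Nc1nc(O)c2c(Cl)cccc2n1`, 4.66 in an assay for inhibition of Dihydrofolate reductase (Homo sapiens); a higher number here means a more potent compound, by a factor of ten per unit of this negative logarithm, a lower number a less potent compound
compound 2, `Nc1ncnc2ccc([S+]([O-])c3ccc4ccccc4c3)cc12`, 4.82 in this assay
compound 3, `Cc1cccc2nc(N)nc(N)c12`, 6.09 in this assay

Compound 3 stands highest of the three numbers, beyond the scatter above both compound 2 and compound 1; the gap to compound 2 is the smaller one, the gap to compound 1 the larger. Compound 4, `Cc1cccc2nc(N)nc(O)c12`, has not yet been measured. It differs from compound 3 in one place: hydroxy in place of amino on an aromatic carbon. Among the compounds with values here, no pair of measured compounds differs in exactly this way, so the step cannot be read off directly. Where compound 3 carries an amino group on the shared core, a hydroxy stands in only one measured compound, though that compound also differs elsewhere; that compound is compound 1, and compound 1 gives 4.66. On that footing the step from compound 3 to compound 4 is expected to be a loss well beyond the scatter, estimated at a number 1.19 log units lower from compound 3 to compound 4 (beyond the scatter). Compound 4 is therefore estimated at 4.9, in a range from 4.2 to 5.6.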

Compound 4, logarithm of the reciprocal of the active concentration, log(1/C): 4.8
The estimate for compound 4 lay 0.10 log units above the measured number; the measured number falls inside the stated range.
By their numbers in this assay, from the lowest: compounds 1, 4 and 2 (each within the scatter of the next); then compound 3.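

In this assay, within the data shown here, the first comparison that changes only this position gives a number 1.29 log units lower from compound 3 to compound 4 (beyond the scatter) for hydroxy in place of amino on an aromatic carbon next to the ring nitrogen, so the amino group in compound 3 counts for much of its standing, with the rest of the molecule held the same. Methyl in place of chloro on an aromatic carbon, with the hydroxy kept, gives a number 0.14 log units higher from compound 1 to compound 4 (within the scatter), so with hydroxy present this swap leaves compound 1 and compound 4 indistinguishable. Nothing at hand bears on why the amino to hydroxy swap costs so much.

As far as these compounds go, whether a methylamino or a methoxy group at this place would hold up like amino or fall like hydroxy remains open. Also open, from the compounds shown here alone, is whether methyl and chloro would still be indistinguishable with the amino group present.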